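Methoxy for methylsulfanyl on the aryl of compound 3

This account rests on a few compounds, and the source may have more. Where it says the series, first, only, none or still open, it means among the compounds named here.

Three compounds have a number in an assay on HEK293 cells for displacement of a labelled ligand from 5-hydroxytryptamine receptor 7 (Homo sapiens), with a stated time of 1 h; on this read-out lower numbers stand for stronger inhibition and higher numbers for weaker inhibition. Compound 1 `COc1ccccc1N1CCN(CCCCC(=O)N2CCC[C@H]2C(N)=O)CC1` gives 634 nM. Compound 2 `NC(=O)[C@@H]1CCCN1C(=O)CCCCCN1CCN(c2noc3ccccc23)CC1` gives 50 nM. Compound 3 `CSc1ccccc1N1CCN(CCCCC(=O)N2Cc3ccccc3C[C@H]2C(N)=O)CC1` gives 51 nM, the second highest of the three; against compound 2 the two numbers lie within the scatter, and against compound 1 the gap is beyond the scatter. Going by the values given here, no pair among them differs in one place only, so no single step is known.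

Compound 4 `COc1ccccc1N1CCN(CCCCC(=O)N2Cc3ccccc3C[C@H]2C(N)=O)CC1` is not yet measured. The change from compound 3 to compound 4 is methoxy in place of methylsulfanyl on an aromatic carbon. Compound 1 carries the same methoxyphenyl on a different core and gives 634 nM, a higher number than compound 3, but the core differs as well, so how much of that gap belongs to the substituent cannot be separated.

The step from compound 3 to compound 4 is expected to be a 2.4-fold higher number from compound 3 to compound 4 (0.37 log units; beyond the scatter), a modest rise in the number, possibly within the scatter. Compound 4 is estimated at 120 nM, with a range from 40 nM to 400 nM.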

Compound 4, inhibition constant: 551 nM
Compound 4: the middle estimate sits 4.6-fold (0.66 log units) below what was measured; the measured number lies above the stated range.
By their numbers in this assay, from the lowest: compounds 2 and 3 (each within the scatter of the next); then compounds 4 and 1 (each within the scatter of the next).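

In this assay, going by these compounds alone, on the shared core, methoxy in place of methylsulfanyl on this aromatic carbon, ortho to a large group, gives an 11-fold higher number from compound 3 to compound 4 (1.03 log units; beyond the scatter), the only single-place step so far and one well beyond the scatter. The two groups match in heavy-atom count, hydrogen-bond donors, hydrogen-bond acceptors and net charge, yet they are not interchangeable at this position on this read-out, so those counts alone do not predict the outcome here. Nothing shown accounts for the size of this step.

Going by these compounds, it remains open whether the same exchange gives a step of similar size on the core of compound 1. On these data alone, how an ethylsulfanyl group, a chlorine atom or a plain hydrogen on this aromatic carbon would read against methylsulfanyl and methoxy also remains open.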